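Exchanging the Halogenated Benzyl Arm for a Trifluoromethyl One

The compounds below may be only part of what the source reports. "The series", "measured", "known", "first", "only" and "open" are said of these compounds alone.

Compound 3 `CCN(Cc1ccccc1Cl)C(=O)C1CCN(S(=O)(=O)c2ccc3cn[nH]c3c2)CC1` gives 93% in a functional assay on CHO cells for positive allosteric modulation of muscarinic acetylcholine receptor M5 (Homo sapiens), read by calcium flux (on this read-out higher numbers stand for larger maximal responses and lower numbers for smaller maximal responses), the highest of the three numbers shown. Compound 2 `CCN(Cc1cccc(OC)c1)C(=O)C1CCN(S(=O)(=O)c2ccc3cn[nH]c3c2)CC1` gives 85%, and the step of a number 8 percentage points higher from compound 2 to compound 3 (within the scatter) means the two cannot be ordered. Compound 1 `CCN(Cc1ccc(F)cc1)C(=O)C1CCN(S(=O)(=O)c2ccc3cn[nH]c3c2)CC1` gives 55%, and the step of a number 38 percentage points higher from compound 1 to compound 3 (beyond the scatter) is large. Compound 4 `CCN(Cc1cccc(C(F)(F)F)c1)C(=O)C1CCN(S(=O)(=O)c2ccc3cn[nH]c3c2)CC1` carries the change (3-(trifluoromethyl)phenyl in place of 2-chlorophenyl on a saturated chain carbon bound to an amide-type nitrogen). Among the measured compounds shown here, the steps that bear on it are a number 38 percentage points higher from compound 1 to compound 3 (beyond the scatter) and a number 8 percentage points higher from compound 2 to compound 3 (within the scatter), since each also exchanges the 2-chlorophenyl group; the first was large, the second small. Because compound 2 gives 85% with a different phenyl group, a step of about a number 10 percentage points lower from compound 3 to compound 4 (within the scatter) is expected, within the scatter. Compound 4 is estimated at 83%, in the range 66% to 98%.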

Compound 4, largest response reached (reported as percent of maximum), in percent of the reference or control that the assay uses: 59%
Estimate against measurement, compound 4: 24 percentage points above; measured number below the stated range.
By their numbers in this assay, from the lowest: compounds 1 and 4 (each within the scatter of the next); then compounds 2 and 3 (each within the scatter of the next).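

A high response in this assay does not follow from any substituent on this phenyl group: with trifluoromethyl in place of methoxy on an aromatic carbon, the result is a number 26 percentage points lower from compound 2 to compound 4 (beyond the scatter). Exchanging the 2-chlorophenyl group is also costly, at a number 34 percentage points lower from compound 3 to compound 4 (beyond the scatter), while a number 4 percentage points higher from compound 1 to compound 4 (within the scatter) leaves the 3-(trifluoromethyl)phenyl group level with the 4-fluorophenyl group. Nothing given here accounts for these steps. Still open, as far as these compounds go, is whether an amine or a carboxylic acid on this phenyl ring would give a response like that of compound 3.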